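Working Notes: Cytotoxicity Limits and an Unmeasured Extension

A few compounds are considered here, and "the series" means these few. Any claim that something is new, unique, unknown or untested is made for them only; others in the source may bear on it.

Measured so far:
Compound 1 `O=[N+]([O-])c1cc(CSc2nnc(-c3ccccc3)n2C2CCCCC2)cc([N+](=O)[O-])c1` — in an ADME assay on HepG2 cells (Homo sapiens) for cytotoxicity, with a stated time of 48 h (a lower number here means a stronger inhibitor, a higher number a weaker inhibitor), compound 1 gives > 30000 nM, a limit of the assay.
Compound 2 `O=[N+]([O-])c1cc(CSc2nnc(C3CCCCC3)n2Cc2ccccc2)cc(C(F)(F)F)c1` — in this assay compound 2 gives > 30000 nM, also a limit.
Compound 3 `CSc1nnc(-c2cc([N+](=O)[O-])cc([N+](=O)[O-])c2)n1Cc1ccccc1` — in this assay compound 3 gives > 30000 nM, again a limit.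

Compound 3 therefore stands at the assay limit, and so do the other two shown values (the limit of > 30000 nM in this assay, at which 3 of the 3 values shown sit). For the measured compounds named here, no step between measured compounds differs in a single place, so no measured step size is available.

Compound 4 `COc1ccc(CSc2nnc(-c3cc([N+](=O)[O-])cc([N+](=O)[O-])c3)n2Cc2ccccc2)cc1` differs from compound 3 by 4-methoxyphenyl in place of hydrogen on a saturated chain carbon bound to a sulfur. With every shown value sitting at the limit, no step beyond the scatter is expected in either direction in this assay. Compound 4 is estimated to remain at or above the limit, about 40000 nM (range 15000 nM to 100000 nM), a step that the limit leaves unreadable from compound 3 to compound 4 that is expected to be within the scatter.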

Compound 4, half-maximal inhibitory concentration: > 30000 nM
Compound 4 ended at the assay's limit; the forecaster's own chance of this, stated with the estimate: 85%; the middle value is on the limit's open side.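

For the compounds shown here, compound 3 and compound 4 both stand at a limit in this assay and no step between them can be read. The compounds shown leave open whether any change to the shared core would give a value inside the assay's range.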